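Swapping the aryl group of compound 3

The source may report more compounds than this note shows. Statements on the series, on what has been measured and on what is new or still open speak of the compounds shown alone.

In a functional assay on A549 cells (Homo sapiens) for antiproliferative activity, read by MTT assay, with a stated time of 72 h (on this read-out lower numbers stand for stronger inhibition and higher numbers for weaker inhibition), compound 3 `COc1cc2ncnc(Nc3cccc(F)c3)c2cc1OCCCN1CCNCCNCCNCC1` gives no number: its result of > 50000 nM is a limit of the assay. Two relatives with the same core and chain do give numbers. Compound 1 `COc1cc2ncnc(Nc3ccc(Br)cc3F)c2cc1OCCCN1CCNCCNCCNCC1` reaches 15200 nM and compound 2 `COc1cc2ncnc(Nc3ccc(F)c(Br)c3)c2cc1OCCCN1CCNCCNCCNCC1` reaches 11800 nM. Between these two the data show a 1.3-fold lower number from compound 1 to compound 2 (0.11 log units; within the scatter).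

Compound 4 `COc1cc2ncnc(Nc3ccc(C#N)cc3F)c2cc1OCCCN1CCNCCNCCNCC1` comes from compound 3 by a single change, 4-cyano-2-fluorophenyl in place of 3-fluorophenyl on a nitrogen on an aromatic ring.

The closest guides are an at least 3.2-fold higher number from compound 1 to compound 3 (0.51 log units; beyond the scatter) and an at least 4.2-fold higher number from compound 2 to compound 3 (0.62 log units; beyond the scatter). Both steps end at the 3-fluorophenyl group that compound 4 gives up, and both start from a bromine-carrying group. No measurement here covers a nitrile. A move back toward lower numbers in this assay is therefore expected, of similar or smaller size than those two steps. The expected change is an at least 2.2-fold lower number from compound 3 to compound 4 (0.35 log units; beyond the scatter). For compound 4 the estimate is 22000 nM, with an expected range from 9000 nM to 50000 nM.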

Compound 4, half-maximal inhibitory concentration: > 50000 nM
Compound 4 ended at the assay's limit (the forecaster's own chance of this, stated with the estimate: 25%); at least 2.2-fold (0.35 log units) between middle value and limit.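

Cyano in place of bromo is the one-place change that isolates the nitrile, and it gives an at least 3.2-fold higher number from compound 1 to compound 4 (0.51 log units; beyond the scatter); in this assay, then, the nitrile does not keep the measurable activity that the bromine gives on this fluorophenyl ring. The comparison with the other bromine-carrying relative points the same way, with an at least 4.2-fold higher number from compound 2 to compound 4 (0.62 log units; beyond the scatter). The step between compound 3 and compound 4 cannot be read, since both results are limits rather than numbers: the limit of > 50000 nM in this assay, at which 2 of the 4 values shown sit.

As far as these compounds go, how far past that limit compound 3 and compound 4 really lie stays open, so neither can be placed ahead of the other. Also open, from the compounds shown here alone, is whether a chlorine or a methoxy group in place of the cyano would bring back a readable number, as the bromine of compound 1 does.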